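Swapping the Amide Substituent on a Shared Sulfonamide Core

This account rests on a few compounds, and the source may have more. Where it says the series, first, only, none or still open, it means among the compounds named here.

Of the compounds shown here, three sharing one core have been tested in a functional assay on SH-SY5Y cells (Homo sapiens), read by MTT assay, with a stated time of 24 h; a higher number here means that more compound is needed for the effect, a lower number that less compound is needed. Compound 1 is `COc1ccc(Cl)cc1N(CC(=O)N1CCc2ccccc21)S(=O)(=O)c1ccccc1` and carries a 2,3-dihydro-1H-indol-1-yl on its carbonyl carbon. Compound 2 is `COc1ccc(Cl)cc1N(CC(=O)Nc1ccccc1)S(=O)(=O)c1ccccc1`, with anilino in that place, and compound 3 is `COc1ccc(CNC(=O)CN(c2cc(Cl)ccc2OC)S(=O)(=O)c2ccccc2)cc1`, with (4-methoxybenzyl)amino there. In this assay compound 1 gives only a limit, > 20000 nM. Compound 2 likewise reaches only a limit, > 20000 nM. Compound 3 also stops at a limit, > 20000 nM, so its standing cannot be placed against the other two beyond saying that all three sit at the same boundary; this is the limit of > 20000 nM in this assay, at which 3 of the 3 values shown sit. The steps among them are therefore a step that the two limits leave unreadable from compound 1 to compound 2, a step that the two limits leave unreadable from compound 1 to compound 3 and a step that the two limits leave unreadable from compound 2 to compound 3, none with a readable size.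

Compound 4 is `COc1ccc(Cl)cc1N(CC(=O)Nc1ccc(Cl)cc1)S(=O)(=O)c1ccccc1`. Its difference from compound 3 is 4-chlorophenyl in place of 4-methoxybenzyl on an amide-type nitrogen. The closest measured comparison is compound 2, whose phenyl on the amide-type nitrogen gave only a limit, and nothing among the three suggests that a 4-chlorophenyl would move the number into the measurable range. Compound 4 is expected to give 30000 nM, between 8000 nM and 100000 nM, a step that the limit leaves unreadable from compound 3 to compound 4 that is most likely again only a limit.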

Compound 4, half-maximal effective concentration: > 20000 nM
Compound 4: only a limit was reported; the forecaster's own chance of this, stated with the estimate: 85%; the middle value lies beyond the limit too.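

In this assay compound 4 gives only a limit, > 20000 nM. The steps from compound 1, compound 2 and compound 3 to compound 4 therefore cannot be read, and all four compounds share one boundary: the limit of > 20000 nM in this assay, at which 4 of the 4 values shown sit. The compounds shown leave open whether any amide substituent on the shared core gives a measurable value.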